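A few compounds are considered here, and "the series" means these few. Any claim that something is new, unique, unknown or untested is made for them only; others in the source may bear on it.

Compound 1 `CNc1cc(Oc2ccc(NC(=O)Nc3cccc(CF)c3)cc2)ncn1` gives 400 nM in an assay on isolated protein for inhibition of serine/threonine-protein kinase TNNI3K (Homo sapiens); a higher number here means a weaker inhibitor, a lower number a stronger inhibitor. Compound 2 `Nc1cc(Oc2ccc(NC(=O)Nc3cccc(C(F)(F)F)c3)cc2)ncn1` gives 25 nM in this assay.

Among the measured compounds shown here, compound 2 has the lower of the two numbers; compound 1 sits a good deal higher, and the two differ in more than one place, so no single step links them. Compound 3 `CN(C)c1cc(Oc2ccc(NC(=O)Nc3cccc(C(F)(F)F)c3)cc2)ncn1` differs from compound 2 in one place only: dimethylamino in place of amino on an aromatic carbon. For the measured compounds named here, no measured pair shows this same change, so the expectation rests on the structural change alone. The step from compound 2 to compound 3 is expected to be modest and upward, near the edge of the scatter, with a 2.8-fold higher number from compound 2 to compound 3 (0.45 log units; beyond the scatter). Compound 3 is estimated at 70 nM, between 25 nM and 250 nM.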

Compound 3, half-maximal inhibitory concentration: 2500 nM
Compound 3: middle estimate off by 36-fold (1.55 log units), on the low side; the whole stated range lies below it.
By their numbers in this assay, from the lowest: compound 2; then compound 1; then compound 3.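

In this assay, replacing amino with dimethylamino on this aromatic carbon, next to the ring nitrogen, gives a 100-fold higher number from compound 2 to compound 3 (2.00 log units; beyond the scatter), a large step that shows the position is far from indifferent to what the nitrogen carries. Amino carries 1 hydrogen-bond donor and dimethylamino carries 0, but this single change also enlarges the group, and the pair cannot separate the two. No evidence here gives a reason for the step. Still open, from the compounds shown here alone, is how an ethylamino group or a morpholine ring would fare at this position, and whether the same change would cost as much with a different group on the urea's far ring.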